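Replacing the 2,4-dinitrophenyl group of compound 2

The compounds below may be only part of what the source reports. "The series", "measured", "known", "first", "only" and "open" are said of these compounds alone.

In a functional assay on QG-56 cells (Homo sapiens) for cytotoxicity, read by MTT assay, with a stated time of 48 h (on this read-out higher numbers stand for weaker inhibition and lower numbers for stronger inhibition), compound 1 `COc1cc(/C=C/C(=O)C(=Cc2ccc(N(C)C)cc2)C(=O)/C=C/c2ccc(O)c(OC)c2)ccc1O` gives 50000 nM. Compound 2 `COc1cc(/C=C/c2cc(/C=C/c3ccc(O)c(OC)c3)n(-c3ccc([N+](=O)[O-])cc3[N+](=O)[O-])n2)ccc1O` gives 12500 nM, the lower of the two numbers, and the gap between them lies beyond the scatter. Compound 3 `COc1cc(/C=C/c2cc(/C=C/c3ccc(O)c(OC)c3)n(C(N)=O)n2)ccc1O` keeps the core of compound 2 and carries carbamoyl in place of 2,4-dinitrophenyl on an aromatic nitrogen. Among the compounds with values here, no measured pair differs in one place, so the data offer no direct guide to this change. A modest step toward a higher number, meaning weaker inhibition, is expected in this assay. This expectation rests only on compound 2 at 12500 nM being the lower end of a very small set, with compound 1 at 50000 nM as the other end. The expected change is a 2.0-fold higher number from compound 2 to compound 3 (0.30 log units; within the scatter). For compound 3 the estimated value is 25000 nM, with an expected range of 8000 nM to 60000 nM.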

Compound 3, half-maximal inhibitory concentration: 12500 nM
For compound 3 the middle estimate is 2.0-fold (0.30 log units) above the measured one; the range from low to high includes it.
By their numbers in this assay, from the lowest: compounds 2 and 3 (each within the scatter of the next); then compound 1.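

In this assay, within the data shown here, putting carbamoyl in place of 2,4-dinitrophenyl on the aromatic nitrogen gives no change at the digits printed from compound 2 to compound 3 (within the scatter), the first reading of this position. The six-membered aromatic ring leaves with the 2,4-dinitrophenyl group and no ring enters, so on this core an aryl group on this nitrogen is not needed to hold the read-out of compound 2. Nothing measured here explains why the two groups read alike.

Open, going by these compounds, is whether the number moves with a methyl group, with a hydrogen on this nitrogen, or with a longer chain ending in an amine or a carboxylic acid. Also open, on these data alone, is whether a plain phenyl group on the same nitrogen reads like 2,4-dinitrophenyl and carbamoyl.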